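A few compounds are considered here, and "the series" means these few. Any claim that something is new, unique, unknown or untested is made for them only; others in the source may bear on it.

Measured compounds:
compound 1 `CC(=O)Oc1ccc2cc(-c3cccs3)c(=O)oc2c1OC(C)=O` — > 100000 nM
compound 2 `CC(=O)Oc1ccc2cc(-c3ccsc3)c(=O)oc2c1OC(C)=O` — > 100000 nM
compound 3 `O=c1oc2c(O)cccc2cc1-c1cccs1` — 3360 nM

In an assay on CHO cells for displacement of a labelled ligand from adenosine receptor A1 (Homo sapiens) (a higher number here means a weaker inhibitor, a lower number a stronger inhibitor), compound 1 gives only a limit, > 100000 nM. Compound 2 likewise gives only a limit in this assay, > 100000 nM. Going by the values given here, compound 3 is the one compound of the three with a number in this assay, 3360 nM. The change from compound 1 to compound 2 is thiophen-3-yl in place of thiophen-2-yl on an aromatic carbon; its step, a step that the two limits leave unreadable from compound 1 to compound 2, cannot be read because both ends sit at the limit of > 100000 nM in this assay, at which 2 of the 3 values shown sit.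

The difference between the core of compound 1 and the core of compound 3 is not broken down here. Compound 4 `O=c1oc2c(O)cccc2cc1-c1ccsc1` is not yet measured in this assay. It differs from compound 3 by thiophen-3-yl in place of thiophen-2-yl on an aromatic carbon, the same change as from compound 1 to compound 2. The only shown occurrence of this change gives no readable size, so the expectation for compound 4 rests on compound 3 alone, with a wide range. The step from compound 3 to compound 4 is expected to be a 1.5-fold higher number from compound 3 to compound 4 (0.17 log units; within the scatter). Compound 4 is estimated at 5000 nM, between 1500 nM and 25000 nM.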

Compound 4, inhibition constant: 5920 nM
The estimate for compound 4 lay 1.2-fold (0.07 log units) below the measured number; measured number inside the range.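

The one readable occurrence of thiophen-3-yl in place of thiophen-2-yl is a 1.8-fold higher number from compound 3 to compound 4 (0.25 log units; within the scatter), so on that core the two thiophene groups cannot be told apart in this assay. The same change on the core of compound 1 cannot be read, with compound 1 and compound 2 each giving a limit and not a number: the limit of > 100000 nM in this assay, at which 2 of the 4 values shown sit A single readable occurrence therefore shows nothing about transfer between cores: it does not show that the change would stay within the scatter on the core of compound 1 or on any other core.

The compounds shown leave open which part of the difference between the core of compound 1 and the core of compound 3 separates their values, and no pair shown isolates one part of it. Also open, going by these compounds, is what a phenyl, a furan-2-yl or an amine in place of the thiophene ring would do in this assay.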